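This account rests on a few compounds, and the source may have more. Where it says the series, first, only, none or still open, it means among the compounds named here.

Among the compounds with values here, in a functional assay on HeLa cells (Homo sapiens) for inhibition, read by MTT assay, with a stated time of 48 h (on this read-out lower numbers stand for stronger inhibition and higher numbers for weaker inhibition), compound 1 (`CCOC(=O)C1=C(N/N=C(/C#N)C(=O)OCC)Nc2[nH]nc(C)c2C1c1ccc(N(C)C)cc1`) gives 39200 nM and compound 2 (`CCOC(=O)C(=NNC1=C(C(=O)OCC)C(c2ccc(N(C)C)cc2)c2c(C)n[nH]c2N1)C(=O)OCC`) gives 83800 nM as the highest of the two numbers so far. The change to compound 3 (`CCOC(=O)C1=C(N/C=N/c2ccc(C)cc2)Nc2[nH]nc(C)c2C1c1ccc(N(C)C)cc1`) is a group of 9 heavy atoms (8 carbon, 1 nitrogen; one six-membered aromatic ring of carbon only) in place of a group of 12 heavy atoms (7 carbon, 1 nitrogen, 4 oxygen; no ring), on an amine nitrogen and no group with a ring has yet been measured at this place. Within the data shown here, the only measured step on that nitrogen is a 2.1-fold higher number from compound 1 to compound 2 (0.33 log units; beyond the scatter) and it is modest, so a similarly modest step toward a lower number is expected in this assay with wide uncertainty. The expected step is a 2.1-fold lower number from compound 2 to compound 3 (0.32 log units; beyond the scatter) on this estimate. Compound 3 is estimated at 40000 nM with 13000 nM to 100000 nM as its range.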

Compound 3, half-maximal inhibitory concentration: 43200 nM
For compound 3 the middle estimate is 1.1-fold (0.03 log units) below the measured one, and the stated range covers the measured number.
By their numbers in this assay, from the lowest: compounds 1, 3 and 2 (each within the scatter of the next, the first and the last beyond it).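

Within the data shown here, compound 3 places the first group with a six-membered aromatic ring of carbon only on this amine nitrogen, and in this assay neither step to it leaves the scatter (a 1.9-fold lower number from compound 2 to compound 3 (0.29 log units; within the scatter)) (a 1.1-fold higher number from compound 1 to compound 3 (0.04 log units; within the scatter)). A ring-bearing group with a single hydrogen-bond acceptor therefore cannot be told apart on this read-out from the open-chain group of compound 2 or that of compound 1. Nothing available explains this result.

Going by these compounds, whether any group at this nitrogen moves the number further remains open. A carboxylic acid, a primary amine or a pyridine ring would test this.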